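The source may hold more compounds than are shown below. What is called first, only, known or untested is meant among the compounds shown, and "the series" means these compounds.

Measured so far:
- compound 1 `c1ccc2c(-c3cnc4[nH]nc(-c5nc6ccccc6[nH]5)c4c3)cncc2c1` — 1700 nM
- compound 2 `COCc1cccc2[nH]c(-c3n[nH]c4ncc(-c5cncnc5)cc34)nc12` — 9910 nM

In a functional assay on HeLa cells (Homo sapiens) for antiproliferative activity (on this read-out lower numbers stand for stronger inhibition and higher numbers for weaker inhibition), compound 1 gives 1700 nM, the lowest of the two numbers; compound 2 gives 9910 nM, a gap beyond the scatter. Among the compounds with values here, the two differ in more than one place, so no single step is drawn between them and their values alone show the difference.

Compound 3 `CC(C)NCc1cccc2[nH]c(-c3n[nH]c4ncc(-c5cncc6ccccc56)cc34)nc12` is compound 1 with (isopropylamino)methyl in place of hydrogen on an aromatic carbon. Within the data shown here, no measured pair in the set isolates this kind of change, so its size is open; the only other substituted compound, compound 2, also carries a different ring and gives 9910 nM, which says nothing clean about the chain alone.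

The expectation is a step from compound 1 to compound 3 of a 1.4-fold lower number from compound 1 to compound 3 (0.15 log units; within the scatter), small and likely within the scatter, with a slight lean toward stronger inhibition. Compound 3 is estimated at 1200 nM, in the range 300 nM to 5000 nM.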

Compound 3, half-maximal inhibitory concentration: 130 nM
Beside the measured number, compound 3's estimate is 9.2-fold (0.97 log units) above it, outside the stated range (below it).
By their numbers in this assay, from the lowest: compound 3; then compound 1; then compound 2.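

In this assay, putting (isopropylamino)methyl in place of hydrogen on an aromatic carbon of the carbon-only six-membered ring gives a 13-fold lower number from compound 1 to compound 3 (1.12 log units; beyond the scatter), a large step beyond the scatter. Within the data shown here, this is the first single-place comparison: compound 1 and compound 2 differ in more than one place and could not show that this position, ortho to a fused ring and meta to a fused ring, both accepts a chain and strongly moves antiproliferative potency. No measurement among the data shown bears on what lies behind the step.

On these data alone, whether the amine nitrogen matters remains open, and a plain propyl chain at this carbon would test that. Also open, as far as these compounds go, is how a cyclic amine such as piperidinylmethyl, or a longer aminoalkyl chain, would compare with (isopropylamino)methyl.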